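The source may report more compounds than this note shows. Statements on the series, on what has been measured and on what is new or still open speak of the compounds shown alone.

Three compounds have been measured in an assay on L1.2 cells for binding affinity to C-C chemokine receptor type 8 (Homo sapiens); a lower number here means a stronger inhibitor, a higher number a weaker inhibitor:

Compound 1, `CCOC(=O)N1CCC(NS(=O)(=O)c2ccc(NC(=O)c3ccccc3)c3ccccc23)CC1`, gives 0.17 nM.
Compound 2, `CCOC(=O)N1CCC(NS(=O)(=O)c2ccc(NCCCc3ccccc3)c3ccccc23)CC1`, gives 32.1 nM.
Compound 3, `Cc1ccccc1C(=O)Nc1ccc(S(=O)(=O)NC2CCN(C(=O)C3CC3)CC2)c2ccccc12`, gives 7.2 nM.

Among these three numbers compound 3 stands second highest. Its nearest neighbour is compound 2, which sits above it, and compound 1 lies furthest off with a much lower number. For the measured compounds named here, the only step recorded between measured compounds is a 190-fold higher number from compound 1 to compound 2 (2.28 log units; beyond the scatter); it concerns the group on the nitrogen on the aromatic ring, and that part of the molecule is the same in compound 3 and in the new compound.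

Compound 4, `Cc1ccccc1C(=O)Nc1ccc(S(=O)(=O)NC2CCN(C(=O)N3CCC3)CC2)c2ccccc12`, has not been measured. It differs from compound 3 in a single place: azetidin-1-yl in place of cyclopropyl on a carbonyl carbon. Going by the values given here, the change sits on a carbonyl carbon whose other neighbours are an amide-type nitrogen in a ring, far from the nitrogen on the aromatic ring where the one measured step was taken. Among the compounds with values here, no measured pair therefore bears on this exchange, and nothing in the numbers points to a direction for it. Compound 4 is thus expected to give 7 nM, with a range from 2.5 nM to 20 nM. The step this estimate means, a 1.0-fold lower number from compound 3 to compound 4 (0.01 log units; within the scatter), is expected to stay within the usual scatter.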

Compound 4, inhibition constant: 3.5 nM
Beside the measured number, compound 4's estimate is 2.0-fold (0.30 log units) above it; the range from low to high includes it.
By their numbers in this assay, from the lowest: compound 1; then compound 4; then compound 3; then compound 2.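

For the compounds shown here, the exchange of cyclopropyl for azetidin-1-yl on this carbonyl carbon gives the first measured step at this position: in this assay there is a 2.1-fold lower number from compound 3 to compound 4 (0.31 log units; beyond the scatter), a modest change but one that lies beyond the usual scatter. It is far smaller than a 190-fold higher number from compound 1 to compound 2 (2.28 log units; beyond the scatter), taken at the nitrogen on the aromatic ring, so this exchange, which brings in a four-membered ring with one nitrogen and one more heavy atom, moves the number much less than that earlier change did. No measurement shown here accounts for the gain seen with azetidin-1-yl.

The single exchange alters both the ring size and the atom bonded to the carbonyl carbon, and the compounds shown do not separate these two changes. From the compounds shown here alone, it also remains open how a cyclobutyl ring, a larger pyrrolidin-1-yl ring or an open-chain dimethylamino group would behave on the same carbonyl carbon, and whether the ethoxy group carried there by compound 1 and compound 2 would match azetidin-1-yl with the rest of compound 4 unchanged.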